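The source may report more compounds than this note shows. Statements on the series, on what has been measured and on what is new or still open speak of the compounds shown alone.

Compound 1, `N#CC1=C(N)Oc2c(c3nc4ccccc4nc3c3ccccc23)C12C(=O)N(Cc1cnnn1-c1ccc(F)cc1)c1ccccc12`, gives in a functional assay on HCT-116 cells (Homo sapiens) for antiproliferative activity, read by MTT assay, with a stated time of 48 h (a higher number here means a weaker inhibitor, a lower number a stronger inhibitor), only a limit, > 50000 nM.
Compound 2, `N#CC1=C(N)Oc2c(c3nc4ccccc4nc3c3ccccc23)C12C(=O)N(Cc1cnnn1-c1cccc(Br)c1)c1ccccc12`, gives in this assay only a limit, > 50000 nM.
Compound 3, `Cc1ccccc1-n1nncc1CN1C(=O)C2(C(C#N)=C(N)Oc3c(N)cc4nc5ccccc5nc4c32)c2ccccc21`, gives in this assay only a limit, > 50000 nM.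

Compound 3 therefore stands at the same place as everything else measured here: none of the three compounds reached a readable number, and all of them sit at the same boundary of the measurement (the limit of > 50000 nM in this assay, at which 3 of the 3 values shown sit). For the measured compounds named here, the only pair that differs in a single place, compound 1 and compound 2, gives a step that cannot be read because both ends are limits a step that the two limits leave unreadable from compound 1 to compound 2.

Compound 4, `Cc1cc(C)cc(-n2nncc2CN2C(=O)C3(C(C#N)=C(N)Oc4c(N)cc5nc6ccccc6nc5c43)c3ccccc32)c1`, differs from compound 3 in one place: 3,5-dimethylphenyl in place of 2-methylphenyl on an aromatic nitrogen. Going by the values given here, no measured step bears on this change, since the one step available is unreadable, so there is no direction or size to carry over. Among the compounds with values here, the only guide is that every compound so far has stayed at the boundary, and compound 4 is expected to do the same, with the expected step that the limit leaves unreadable from compound 3 to compound 4 being essentially none. Compound 4 is thus estimated at 60000 nM, within a range from 15000 nM to 250000 nM, most likely reported again only as a limit.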

Compound 4, half-maximal inhibitory concentration: > 50000 nM
Compound 4 ended at the assay's limit; the forecaster's own chance of this, stated with the estimate: 75%; the middle value is on the limit's open side.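

The step from compound 3 to compound 4 cannot be read, since both compounds give only a limit rather than a number. All the compounds shown share one boundary: the limit of > 50000 nM in this assay, at which 4 of the 4 values shown sit.

What they leave open is which structural change, if any, would bring a readable value in this assay.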